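Mixed ester variant of the dihydropyridine thiazole series

The compounds below may be only part of what the source reports. "The series", "measured", "known", "first", "only" and "open" are said of these compounds alone.

Measured so far:
compound 1, `CC1=C(C(=O)OC2CCCCC2)C(c2csc(-c3ccc(Cl)cc3)n2)C(C(=O)OC2CCCCC2)=C(C)N1`, 11000 nM
compound 2, `COC(=O)C1=C(C)NC(C)=C(C(=O)OC(C)(C)C)C1c1csc(-c2ccc(Cl)cc2)n1`, 46000 nM

In an assay on isolated protein for antagonist activity at Voltage-dependent L-type calcium channel subunit alpha-1C (Cavia porcellus), with a stated time of 15 min (on this read-out higher numbers stand for weaker inhibition and lower numbers for stronger inhibition), compound 2 gives 46000 nM, the highest of the two numbers shown; compound 1 stands nearest with a number lower by a margin beyond the scatter. Compound 3, `COC(=O)C1=C(C)NC(C)=C(C(=O)OC2CCCCC2)C1c1csc(-c2ccc(Cl)cc2)n1`, is not yet measured. The change from compound 2 to compound 3 is cyclohexyl in place of tert-butyl on an oxygen next to a carbonyl group. Among the measured compounds shown here, no step between measured compounds isolates this change, so the expectation rests on the two values alone: compound 1 carries cyclohexyl on both esters and gives 11000 nM, while compound 2 carries none. A step down in this assay, falling between the two measured compounds, is expected, a 2.1-fold lower number from compound 2 to compound 3 (0.32 log units; beyond the scatter). Compound 3 is therefore estimated at 22000 nM, with a range from 8000 nM to 60000 nM.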

Compound 3, half-maximal inhibitory concentration: 71900 nM
The estimate for compound 3 lay 3.3-fold (0.51 log units) below the measured number; the measured number lies above the stated range.
By their numbers in this assay, from the lowest: compound 1; then compounds 2 and 3 (each within the scatter of the next).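

In this assay, with a methyl ester kept on the other side, cyclohexyl in place of tert-butyl on an oxygen next to a carbonyl group gives a 1.6-fold higher number from compound 2 to compound 3 (0.19 log units; within the scatter), so this read-out does not separate these two groups at this position. Among the compounds shown here, with one cyclohexyl ester held constant, methyl in place of cyclohexyl on an oxygen next to a carbonyl group gives a 6.5-fold higher number from compound 1 to compound 3 (0.82 log units; beyond the scatter), the only single-place step here that clears the scatter. No supporting data are available to explain either step.

Still open, as far as these compounds go, is how a benzyl group, a longer chain such as n-butyl, or a free carboxylic acid in place of the ester would read at this position. Also open, from the compounds shown here alone, is whether the step seen with methyl in place of cyclohexyl would hold on a core carrying something other than the 4-chlorophenyl group.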